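The source may hold more compounds than are shown below. What is called first, only, known or untested is meant among the compounds shown, and "the series" means these compounds.

Compound 1 `O=C(Nc1cccc(Cl)c1)c1cc(Br)cc(Br)c1O` gives 29000 nM in an assay for inhibition of HSP60/HSP10 (Homo sapiens), with a stated time of 60 min; on this read-out higher numbers stand for weaker inhibition and lower numbers for stronger inhibition.
Compound 2 `O=C(Nc1ccccc1)c1cccc(Br)c1` gives > 100000 nM in this assay, a limit of the assay rather than a number.
Compound 3 `O=C(Nc1cccc(Cl)c1)c1cc(Br)cc(Br)c1` gives > 100000 nM in this assay, again only a limit.

For compound 3 nothing but a limit is known in this assay; it sits at the limit of > 100000 nM in this assay, at which 2 of the 3 values shown sit. Among the compounds with values here, the only numbered value in the set belongs to compound 1, and the one measured step, an at least 3.4-fold higher number from compound 1 to compound 3 (0.53 log units; beyond the scatter), runs from that number out to the limit.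

Compound 4 `O=C(Nc1cccc(Cl)c1)c1cccc(Br)c1` is reached from compound 3 by hydrogen in place of bromo on an aromatic carbon, the change sitting meta to a bromo group. Within the data shown here, no measured step removes a bromo group, so the single measured step concerns a different change and does not bear on this one directly. What remains is that compound 2, which likewise carries a single bromo, also stands at the limit. The expectation in this assay is therefore no move beyond the scatter, with compound 4 expected to remain at the limit, the expected step being a step that the limit leaves unreadable from compound 3 to compound 4. Compound 4 is estimated at 150000 nM, with a range from 60000 nM to 500000 nM.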

Compound 4, half-maximal inhibitory concentration: > 100000 nM
Compound 4: no number, only a limit; the forecaster's own chance of this, stated with the estimate: 85%; the middle value lies beyond the limit too.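

In this assay compound 4 gives > 100000 nM, a limit of the assay and not a number. No step from compound 3 or compound 2 to compound 4 can be read, as all three stand at the same limit: the limit of > 100000 nM in this assay, at which 3 of the 4 values shown sit.

The compounds shown leave open what the second bromo group or the chloro group contributes, with compound 1 the only one holding a number.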